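Phenyl for pyrazolyl at the benzylic carbon of compound 1

The source may report more compounds than this note shows. Statements on the series, on what has been measured and on what is new or still open speak of the compounds shown alone.

Among the measured compounds shown here, compound 1 `O=C(O)/C=C/c1ccc(Cn2cccn2)cc1OCCc1ccc2ccccc2c1` is the one member of the series with a numerical value: in an assay on CHO cells for displacement of a labelled ligand from prostaglandin E2 receptor EP1 subtype (Mus musculus), read by scintillation counting (on this read-out higher numbers stand for weaker inhibition and lower numbers for stronger inhibition), compound 1 gives 2900 nM. Compound 2 `O=C(O)/C=C/c1ccc(Cn2ccnc2)cc1OCCCOc1ccccc1` returns only a limit of the assay, since in this assay compound 2 gives > 10000 nM. For the measured compounds named here, that limit, (the limit of > 10000 nM in this assay, at which 1 of the 2 values shown sits), is the only other point, so no step between measured compounds exists and nothing can be checked against a neighbouring pair. Compound 3 `O=C(O)/C=C/c1ccc(Cc2ccccc2)cc1OCCc1ccc2ccccc2c1` differs from compound 1 by phenyl in place of 1H-pyrazol-1-yl on a saturated chain carbon bound to an aromatic carbon; the remainder of the shared core is unchanged. Going by the values given here, with no measured step of this kind to lean on, the expectation is a step from compound 1 to compound 3 of a 1.2-fold lower number from compound 1 to compound 3 (0.06 log units; within the scatter), which stays within the usual scatter in either direction. In this assay compound 3 is therefore expected to give about 2500 nM, estimated between 600 nM and 10000 nM.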

Compound 3, inhibition constant: > 10000 nM
Compound 3 ended at the assay's limit; the forecaster's own chance of this, stated with the estimate: 20%; middle value at least 4.0-fold (0.60 log units) away from the limit.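

Swapping 1H-pyrazol-1-yl for phenyl on a saturated chain carbon bound to an aromatic carbon gives, in this assay, an at least 3.4-fold higher number from compound 1 to compound 3 (0.53 log units; beyond the scatter). Compound 3 gives > 10000 nM, which is a limit of the assay. This gives the series its first readable step, showing that at this position, with the rest of the shared core unchanged, the two aromatic rings are not interchangeable, although the true size of the step stays hidden: the limit of > 10000 nM in this assay, at which 2 of the 3 values shown sit.

Steps involving compound 2 cannot be read, as it differs from the others in more than one place or sits at the same limit. As far as these compounds go, whether a pyridine ring, an amine or a carboxylic acid on this carbon would keep, lower or raise the number of compound 1 remains open, as does whether the nitrogen atoms of the pyrazole ring matter at all.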